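This account rests on a few compounds, and the source may have more. Where it says the series, first, only, none or still open, it means among the compounds named here.

Measured compounds:
compound 1 `COc1ccc(C(=O)N(Cc2ccncc2)Cc2cccc(OCC3CCOCC3)c2)cc1` gives 17700 nM in a functional assay on KMS-11 cells (Homo sapiens) for antiproliferative activity, read by CellTiter-Glo, with a stated time of 72 h; on this read-out higher numbers stand for weaker inhibition and lower numbers for stronger inhibition;
compound 2 `COc1ccc(C(=O)N(Cc2ccncc2)Cc2cccc(OCCc3ccccc3)c2)cc1` gives 16900 nM in this assay.

Compound 2 stands at the lower of the two numbers, but the step of a 1.0-fold lower number from compound 1 to compound 2 (0.02 log units; within the scatter) is within the scatter, so the two compounds cannot be told apart on this read-out. Both are weak inhibitors of cell growth.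

Compound 3 `COc1ccc(C(=O)N(Cc2ccncc2)Cc2cccc(OCc3cccc(OC)c3)c2)cc1` is the next step from compound 2. The change is 3-methoxyphenyl in place of benzyl on a saturated chain carbon bound to an oxygen on an aromatic ring. Going by the values given here, the one measured step, from compound 1 to compound 2, also swapped the group on a saturated chain carbon bound to an oxygen on an aromatic ring, and it left the number essentially unchanged (a 1.0-fold lower number from compound 1 to compound 2 (0.02 log units; within the scatter)). Among the compounds with values here, there is no measured step that swaps a benzyl for a 3-methoxyphenyl, so the only guide is that the earlier swap at the same place made no difference beyond the scatter.

On that basis compound 3 is expected to stay close to compound 2 in this assay, with a step of a 1.0-fold higher number from compound 2 to compound 3 (0.00 log units; within the scatter), that is, none beyond the scatter. The estimated value for compound 3 is 17000 nM, within a range from 8000 nM to 36000 nM.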

Compound 3, half-maximal inhibitory concentration: 16900 nM
For compound 3 the middle estimate is 1.0-fold (0.00 log units) above the measured one; measured number inside the range.
By their numbers in this assay, from the lowest: compounds 2, 3 and 1 (each within the scatter of the next).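

The step of no change at the digits printed from compound 2 to compound 3 (within the scatter) adds a third group to the two already compared at this place, and this one carries a methoxy oxygen, counted as a hydrogen-bond acceptor, which benzyl lacks. Set against the saturated oxan-4-yl group, the same group gives a 1.0-fold lower number from compound 1 to compound 3 (0.02 log units; within the scatter), so all three compounds now lie within the scatter of one another, and in this assay this position has not yet separated a saturated ring, a plain aromatic ring and a methoxy-bearing aromatic ring. No independent measurement is available to account for this sameness.

The compounds shown leave open whether any group at this place can move the number beyond the scatter, since only three neutral ring-bearing groups appear here. An amine, a carboxylic acid or a longer chain on the saturated chain carbon bound to the oxygen on the aromatic ring would put that question to a real test.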